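A few compounds are considered here, and "the series" means these few. Any claim that something is new, unique, unknown or untested is made for them only; others in the source may bear on it.

Of the compounds shown here, two have been measured in a functional assay on SW 1116 cells (Homo sapiens) for antiproliferative activity, read by MTT assay, with a stated time of 48 h; a lower number here means a stronger inhibitor, a higher number a weaker inhibitor. Compound 1, with the structure `Brc1ccc(CSc2nnc(-c3cnccn3)s2)cc1`, gives 1470 nM in this assay. Compound 2, with the structure `Brc1cccc(CSc2nnc(-c3cnccn3)n2-c2ccccc2)c1`, gives 5030 nM in this assay, the higher of the two numbers, and the gap between the two values lies beyond the usual scatter of repeated measurements. Among the compounds with values here, since the two compounds differ in more than one place, the two values show only that compound 2 is the weaker inhibitor of the pair, not which part of the structure accounts for the difference.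

The next compound to be measured is compound 3, with the structure `c1ccc(CSc2nnc(-c3cnccn3)n2-c2ccccc2)cc1`. It differs from compound 2 in one place: hydrogen in place of bromo on an aromatic carbon. Within the data shown here, no measured pair in this set separates the effect of this single change, so nothing here tells how much the bromo group contributes. For this reason the step is expected to be small, most likely within the scatter, with a slight lean towards a higher number; the estimated step from compound 2 to compound 3 is a 1.4-fold higher number from compound 2 to compound 3 (0.14 log units; within the scatter). In this assay compound 3 is expected to give about 7000 nM, with a plausible range from 2500 nM to 20000 nM.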

Compound 3, half-maximal inhibitory concentration: 15400 nM
Beside the measured number, compound 3's estimate is 2.2-fold (0.34 log units) below it; low and high end bracket the measured number.
By their numbers in this assay, from the lowest: compound 1; then compound 2; then compound 3.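

Within the data shown here, for the first time a single change can be read on its own: replacing the bromo group with hydrogen, which turns 3-bromobenzyl into benzyl, gives a 3.1-fold higher number from compound 2 to compound 3 (0.49 log units; beyond the scatter) in this assay. With the rest of the structure unchanged, the bromo group on this aromatic carbon therefore goes with stronger inhibition, so this position is not indifferent to what it carries, at least in this pair. Nothing measured alongside these numbers accounts for the step.

Still open, going by these compounds, is whether a different group on this carbon, such as chloro, methoxy or an amine, would match, exceed or fall short of bromo, and whether bromo would have the same effect on another carbon of this ring. The steps from compound 1 to compound 2 and compound 3 cannot be read, since compound 1 differs from each of them in more than one place, so it cannot yet be said how this change would behave on the core of compound 1.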